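A few compounds are considered here, and "the series" means these few. Any claim that something is new, unique, unknown or untested is made for them only; others in the source may bear on it.

Measured compounds in the series:
- compound 1 `CCCCN(C)c1nc(C(C)(C)C)ccc1CNC(=O)C(C)c1ccc(NS(C)(=O)=O)c(F)c1` gives 1.2 nM in an assay on cells for antagonist activity at transient receptor potential cation channel subfamily V member 1 (Homo sapiens), read by FLIPR and calcium flux, with a stated time of 6 min; on this read-out lower numbers stand for stronger inhibition and higher numbers for weaker inhibition
- compound 2 `CC(C(=O)NCc1ccc(C(C)(C)C)nc1N1CCCCCC1)c1ccc(NS(C)(=O)=O)c(F)c1` gives 0.9 nM
- compound 3 `CCCOc1nc(C(C)(C)C)ccc1CNC(=O)C(C)c1ccc(NS(C)(=O)=O)c(F)c1` gives 1.7 nM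

Compound 2 gives the lowest number of the three; the nearer step is a 1.3-fold lower number from compound 1 to compound 2 (0.12 log units; within the scatter) and the further step is a 1.9-fold higher number from compound 2 to compound 3 (0.28 log units; within the scatter). Both gaps lie within the scatter, so no order among the three is claimed: the three groups on this aromatic carbon give numbers that cannot be told apart.

Compound 4 `CC(C(=O)NCc1ccc(C(C)(C)C)nc1OCc1ccc(F)cc1)c1ccc(NS(C)(=O)=O)c(F)c1` is not yet measured. Compared with compound 2, the change is (4-fluorobenzyl)oxy in place of azepan-1-yl on an aromatic carbon.

The most pertinent measured step is the one in which an oxygen-linked group replaces azepan-1-yl on the same aromatic carbon, a 1.9-fold higher number from compound 2 to compound 3 (0.28 log units; within the scatter), within the scatter. The step of a 1.4-fold higher number from compound 1 to compound 3 (0.15 log units; within the scatter) is likewise within the scatter. Within the data shown here, the (4-fluorobenzyl)oxy group enters with more heavy atoms than propoxy and carries an aromatic ring, which none of the measured groups at this place does, so the measured steps cover it only in part. Given that both measured ether-for-amine comparisons stay within the scatter, the expected step is a 2.2-fold higher number from compound 2 to compound 4 (0.35 log units; beyond the scatter), small and toward a higher number, with a wider range than the measured steps would alone suggest. The estimate for compound 4 is 2 nM, between 0.6 nM and 7 nM.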

Compound 4, inhibition constant: 0.8 nM
For compound 4 the middle estimate is 2.5-fold (0.40 log units) above the measured one, within the range that was stated.
By their numbers in this assay, from the lowest: compounds 4, 2, 1 and 3 (each within the scatter of the next, the first and the last beyond it).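

At this aromatic carbon next to the ring nitrogen, a six-membered aromatic ring of carbon only now appears, and in this assay the exchange of the amine-linked groups for (4-fluorobenzyl)oxy gives a 1.1-fold lower number from compound 2 to compound 4 (0.05 log units; within the scatter) and a 1.5-fold lower number from compound 1 to compound 4 (0.18 log units; within the scatter), so compound 4 cannot be told apart from either compound with an amine-linked group. Within the oxygen-linked pair, 4-fluorophenyl in place of ethyl on the saturated chain carbon bound to the oxygen gives a 2.1-fold lower number from compound 3 to compound 4 (0.33 log units; beyond the scatter), the first step at this place to lie beyond the scatter, though it is modest and rests on this single pair. No accompanying data bear on the origin of this step.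

The compounds shown leave open whether the lower number of compound 4 relative to compound 3 belongs to the aromatic ring or to its fluorine, a question that a plain benzyloxy group would address. They also leave open whether the oxygen link matters once the aromatic ring is present, which a benzylamino group at the same carbon would test directly against compound 4.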